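A chloropyridinyl amide weighed against its chlorophenyl kin

The compounds below may be only part of what the source reports. "The series", "measured", "known", "first", "only" and "open" are said of these compounds alone.

Three amides built on a shared core have been measured in a functional assay on A549 cells (Homo sapiens) for antiproliferative activity, read by MTT assay, with a stated time of 72 h; a higher number here means a weaker inhibitor, a lower number a stronger inhibitor. Compound 1 `O=C(Nc1ccc(Cl)c(-c2nnc3c(Cl)cccn23)c1)c1ccc(C(F)(F)F)cc1Cl` reports > 100000 nM, which is a limit of the assay rather than a number; it marks (the limit of > 100000 nM in this assay, at which 1 of the 3 values shown sits). Compound 2 `O=C(Nc1ccc(Cl)c(-c2nnc3c(Cl)cccn23)c1)c1ccc(Cl)cc1` gives 73600 nM in this assay, and compound 3 `O=C(Nc1ccc(Cl)c(-c2nnc3c(Cl)cccn23)c1)c1cccc(Cl)c1` gives 52700 nM. Compound 2 stands alongside compound 3, the two numbers lying within the scatter of each other, while compound 1 sits only at the limit.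

Compound 4 `O=C(Nc1ccc(Cl)c(-c2nnc3c(Cl)cccn23)c1)c1cccnc1Cl` has not been measured. Relative to compound 2 the change is 2-chloropyridin-3-yl in place of 4-chlorophenyl on a carbonyl carbon. For the measured compounds named here, the one measured step that touches this part of the molecule is a 1.4-fold lower number from compound 2 to compound 3 (0.15 log units; within the scatter), a move of the chlorine around the same ring without a change beyond the scatter. Going by the values given here, no measured step introduces a ring nitrogen here, so the expectation rests on that single, small step. Compound 4 is therefore expected to show a 1.1-fold lower number from compound 2 to compound 4 (0.02 log units; within the scatter), a step not beyond the scatter, with an estimated value of 70000 nM in this assay, in the range 30000 nM to 150000 nM.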

Compound 4, half-maximal inhibitory concentration: 35800 nM
For compound 4 the middle estimate is 2.0-fold (0.29 log units) above the measured one, and the stated range covers the measured number.
By their numbers in this assay, from the lowest: compounds 4, 3 and 2 (each within the scatter of the next, the first and the last beyond it). At a limit, above all of these: compound 1.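

For the compounds shown here, on the carbonyl carbon, the 2-chloropyridin-3-yl group gives the first step that clears the scatter in this assay (a 2.1-fold lower number from compound 2 to compound 4 (0.31 log units; beyond the scatter)), which moving the chlorine around the carbon-only ring had not done. Against the 3-chlorophenyl group the same ring stays within the scatter (a 1.5-fold lower number from compound 3 to compound 4 (0.17 log units; within the scatter)), so the modest gain holds against the 4-chlorophenyl group alone. This step brings in the ring nitrogen and changes the chlorine's place together, the data do not separate the two, and nothing shown accounts for the step.

The compounds shown leave open what a pyridinyl ring without the chlorine would give. They also leave open whether an amine or a methoxy group in place of that chlorine would shift the number beyond the scatter.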